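A Methyl Added on the Phenyl of Compound 2

A few compounds are considered here, and "the series" means these few. Any claim that something is new, unique, unknown or untested is made for them only; others in the source may bear on it.

Of the compounds shown here, two have been tested in an assay on brain for inhibition of Fatty-acid amide hydrolase 1 (Rattus norvegicus), read by scintillation counting, with a stated time of 10 min; a lower number here means a stronger inhibitor, a higher number a weaker inhibitor. Compound 1, `CC(C)Cc1ccc(C(C)C(=O)NCc2cccc(C(F)(F)F)c2)cc1`, gives 28000 nM in this assay. Compound 2, `CC(C)Cc1ccc(C(C)C(=O)N2CCN(c3ccccc3)CC2)cc1`, gives 4700 nM in this assay, the lower of the two numbers, and the gap between the two lies beyond the scatter. Compound 3, `Cc1cccc(N2CCN(C(=O)C(C)c3ccc(CC(C)C)cc3)CC2)c1`, has not yet been measured. It differs from compound 2 in one place: methyl in place of hydrogen on an aromatic carbon, sitting meta to a large group, so that the phenyl becomes a 3-methylphenyl. For the measured compounds named here, no pair of measured compounds differs by just this change, so nothing among the data shows how large such a step is. The expectation is for a small step, within the scatter, in either direction, from compound 2 to compound 3 of about a 1.3-fold lower number from compound 2 to compound 3 (0.13 log units; within the scatter). Compound 3 is thus expected to give roughly 3500 nM in this assay, with a likely range from 1200 nM to 10000 nM.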

Compound 3, half-maximal inhibitory concentration: 16000 nM
Estimate against measurement, compound 3: 4.6-fold (0.66 log units) below; the measured number lies above the stated range.
By their numbers in this assay, from the lowest: compound 2; then compounds 3 and 1 (each within the scatter of the next).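

In this assay, for the compounds shown here, the change from phenyl to 3-methylphenyl brings a 3.4-fold higher number from compound 2 to compound 3 (0.53 log units; beyond the scatter) and so gives the first direct reading of a single change. It shows that this position on the phenyl of compound 2 is not indifferent to substitution: one added carbon, on an aromatic carbon and meta to a large group, weakens inhibition by more than the usual scatter. The data shown offer no measured explanation for this loss.

This single step cannot show whether the loss is specific to methyl or would also follow from another group at this position, such as a fluorine atom, a methoxy group or an amine. It also leaves open how a methyl would fare on a different carbon of the same phenyl.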